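The compounds below may be only part of what the source reports. "The series", "measured", "known", "first", "only" and "open" are said of these compounds alone.

Working notes on the series.

Compound 1 `COc1ccccc1Oc1ccc2c(NCCCNCc3ccco3)ccnc2c1` and compound 2 `c1coc(CNCCCNc2ccnc3cc(-c4cccc5ccccc45)ccc23)c1` share one core and differ only in the group on an aromatic carbon of it. In a physicochemical assay for acid dissociation, compound 1 gives 9.28, and compound 2 gives 9.47. For the measured compounds named here, the single step so far, a number 0.19 log units higher from compound 1 to compound 2 (within the scatter), is within the scatter, so the two numbers cannot be ordered. Compound 2 holds the highest of the two numbers shown, its nearest neighbour being compound 1.

Compound 3 `N#Cc1ccc(Cc2ccc3c(NCCCNCc4ccco4)ccnc3c2)cc1` is the next member. The change from compound 2 to compound 3 is 4-cyanobenzyl in place of naphthalen-1-yl on an aromatic carbon. Going by the values given here, only one measured step bears on it, the exchange at the same aromatic carbon from compound 1 to compound 2, and that step was within the scatter. Among the compounds with values here, with a single step of that size as the only guide, the expected step in this assay, a number 0.12 log units lower from compound 2 to compound 3 (within the scatter), is none beyond the scatter. For compound 3 the estimate in this assay is therefore 9.35, with a range from 9 to 9.7.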

Compound 3, acid dissociation constant: 9.47
Compound 3: the middle estimate sits 0.12 log units below what was measured, within the range that was stated.
By their numbers in this assay, from the lowest: compounds 1, 2 and 3 (each within the scatter of the next).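

In this assay, the exchange of naphthalen-1-yl for 4-cyanobenzyl on the aromatic carbon gives a step that stays within the scatter (no change at the digits printed from compound 2 to compound 3 (within the scatter)), and the exchange of 2-methoxyphenoxy for 4-cyanobenzyl does the same (a number 0.19 log units higher from compound 1 to compound 3 (within the scatter)). The position has now carried three different groups, and the new one brings features absent from naphthalen-1-yl: one six-membered aromatic ring of carbon only in place of two, a triple bond outside aromatic rings and a hydrogen-bond acceptor, yet the three compounds cannot be ordered and none of them goes against this flat picture. No measurement is available that explains why the number stays within the scatter across these exchanges.

Whether this flat picture holds for an aliphatic amine or a carboxylic acid on the same aromatic carbon stays open, since all three groups shown are neutral and each carries a six-membered aromatic ring of carbon only. The compounds shown also share one side chain, so a longer chain in its place, or another ring instead of the furan, remains an open question for this read-out.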